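A few compounds are considered here, and "the series" means these few. Any claim that something is new, unique, unknown or untested is made for them only; others in the source may bear on it.

The study concerns two chalcones built on the same hydroxyphenyl ketone core, which differ only in where a bromo group sits on the second ring. In a functional assay on HCT-116 cells (Homo sapiens) for cytotoxicity, read by MTT assay, with a stated time of 48 h, tested at 10 uM (on this read-out lower numbers stand for a stronger effect and higher numbers for a weaker effect at the one concentration tested), compound 1 `O=C(/C=C/c1ccc(Br)cc1)c1ccccc1O` gives 85.5%, whereas compound 2 `O=C(/C=C/c1cccc(Br)c1)c1ccccc1O` gives 48.4%. Compound 2 therefore stands lowest of the two numbers that have been measured, and the gap to compound 1 lies beyond the scatter of the method, so compound 2 shows the stronger effect of the pair on this read-out.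

Compound 3 `O=C(/C=C/c1cccc(Cl)c1)c1ccccc1O` is the next compound in this series. It differs from compound 2 in one place: chloro in place of bromo on an aromatic carbon. Going by the values given here, no measured pair shows what such an exchange does here, so the expectation can rest only on the closeness of the two halogens. The step from compound 2 to compound 3 is expected to be small, a number 9.6 percentage points higher from compound 2 to compound 3 (within the scatter), leaning toward a slightly weaker effect but not clearly beyond the scatter. Compound 3 is accordingly expected to give about 58%, with a plausible range from 35% to 82%.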

Compound 3, a percentage reported as activity, at one concentration (the size of the read-out at that concentration, not a potency): 75.8%
The estimate for compound 3 lay 17.8 percentage points below the measured number; low and high end bracket the measured number.
By their numbers in this assay, from the lowest: compound 2; then compounds 3 and 1 (each within the scatter of the next).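

In this assay, replacing bromo with chloro on this aromatic carbon, meta to a large group, gives a number 27.4 percentage points higher from compound 2 to compound 3 (beyond the scatter). The earlier compounds shown here showed only that the place of the bromo group matters on this read-out; this pair shows that, at this one place, the identity of the halogen matters as well, with bromo giving the stronger effect of the two. Nothing available here accounts for this difference between the two halogens.

Going by these compounds, it remains open whether the same exchange would have a comparable effect at the place the bromo group occupies in compound 1. On these data alone, it is also open how an amine, a methoxy group or a carboxylic acid at this place would compare, and, with one concentration tested, how the effects of the compounds would compare at other concentrations.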